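Aminophenyl variations on the anilino quinazoline core

This account rests on a few compounds, and the source may have more. Where it says the series, first, only, none or still open, it means among the compounds named here.

Compound 1 `Fc1cccc(Nc2nc(-c3cccc(F)c3)nc3ccc(F)cc23)c1` is the reference point of this small set. In a functional assay on U2OS cells (Homo sapiens) for cytotoxicity, read by MTT assay, with a stated time of 48 h (on this read-out lower numbers stand for stronger inhibition and higher numbers for weaker inhibition), compound 1 gives 49600 nM. Two neighbours differ only in the aryl group on the nitrogen on the aromatic ring. Compound 3 `Nc1ccc(Nc2nc(-c3cccc(F)c3)nc3ccc(F)cc23)cc1` carries a 4-aminophenyl there and in this assay compound 3 gives 44200 nM; the step of a 1.1-fold lower number from compound 1 to compound 3 (0.05 log units; within the scatter) does not separate the two compounds. Compound 2 `Fc1cccc(-c2nc(Nc3ccccc3Br)c3cc(F)ccc3n2)c1` carries a 2-bromophenyl and in this assay compound 2 reaches only a limit, > 50000 nM, so a number no lower from compound 1 to compound 2 (the limit leaves the size open) has no readable size; the limit is noted as the limit of > 50000 nM in this assay, at which 1 of the 3 values shown sits.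

Compound 4 `Nc1ccccc1Nc1nc(-c2cccc(F)c2)nc2ccc(F)cc12` is not yet measured. Against compound 1 the change is 2-aminophenyl in place of 3-fluorophenyl on a nitrogen on an aromatic ring. The nearest measured steps are a 1.1-fold lower number from compound 1 to compound 3 (0.05 log units; within the scatter), which stayed within the scatter, and a number no lower from compound 1 to compound 2 (the limit leaves the size open), which gave no number at all. Both point to weak or flat behaviour on this read-out, and nothing among the three measured compounds suggests a gain beyond the scatter. For this assay the expected step is therefore a 1.1-fold lower number from compound 1 to compound 4 (0.03 log units; within the scatter), with a fair chance that only a limit is returned. Compound 4 is expected to give an estimate of 46000 nM, in the range 20000 nM to 100000 nM.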

Compound 4, half-maximal inhibitory concentration: 37900 nM
Beside the measured number, compound 4's estimate is 1.2-fold (0.08 log units) above it, and the stated range covers the measured number.
By their numbers in this assay, from the lowest: compounds 4, 3 and 1 (each within the scatter of the next). At a limit, above all of these: compound 2.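

In this assay the 2-aminophenyl group on the nitrogen on an aromatic ring is not separated from the 3-fluorophenyl group (a 1.3-fold lower number from compound 1 to compound 4 (0.12 log units; within the scatter)) or from the 4-aminophenyl group (a 1.2-fold lower number from compound 3 to compound 4 (0.07 log units; within the scatter)), so moving the amino group on this phenyl produces no readable change across compounds 3 and 4. As far as these compounds go, the new pair of compound 2 and compound 4 adds amino in place of bromo on an aromatic carbon (an at least 1.3-fold lower number from compound 2 to compound 4 (0.12 log units; that floor lies within the scatter)), but that step gives only a floor, so its true size remains unknown. Compound 2 still gives a limit, not a number: the limit of > 50000 nM in this assay, at which 1 of the 4 values shown sits.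

Compounds 1, 3 and 4 all lie within the scatter of their neighbours, so these compounds show no substituent on this phenyl that moves the number beyond the scatter, and no substituent that clearly weakens it apart from the open limit of compound 2. From the compounds shown here alone, whether a carboxylic acid, a dimethylamino group or a longer chain such as aminoethyl at this place would shift the number remains open, as does the effect of a 3-aminophenyl group.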